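Oxygen-to-sulfur core swap and aryl halide change in antiproliferative series

The source may hold more compounds than are shown below. What is called first, only, known or untested is meant among the compounds shown, and "the series" means these compounds.

Measured compounds:
compound 1, `NC1=NC2(CCOCC2)N(OCCCOc2ccccc2Cl)C(N)=N1`, in a functional assay on A549 cells (Homo sapiens) for antiproliferative activity, read by MTT assay, with a stated time of 72 h (a lower number here means a stronger inhibitor, a higher number a weaker inhibitor), compound 1 gives 2700 nM
compound 2, `NC1=NC2(CCOCC2)N(OCCCOc2cccc(Br)c2)C(N)=N1`, in this assay compound 2 gives 160 nM
compound 3, `NC1=NC2(CCSCC2)N(OCCCOc2ccccc2Cl)C(N)=N1`, in this assay compound 3 gives 80 nM

Compound 3 stands lowest of the three numbers; its gap to compound 2 is within the scatter, its gap to compound 1 is beyond it. The difference between the core of compound 1 and the core of compound 3 is not broken down here.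

From compound 1 to compound 2 the change is 3-bromophenyl in place of 2-chlorophenyl on an oxygen on a saturated carbon; this gave a 17-fold lower number from compound 1 to compound 2 (1.23 log units; beyond the scatter).

Compound 4, `NC1=NC2(CCSCC2)N(OCCCOc2cccc(Br)c2)C(N)=N1`, is not yet measured. It differs from compound 3 by 3-bromophenyl in place of 2-chlorophenyl on an oxygen on a saturated carbon, the same change as from compound 1 to compound 2, at the same place.

The step from compound 3 to compound 4 in this assay is expected to be a 4.0-fold lower number from compound 3 to compound 4 (0.60 log units; beyond the scatter), smaller than the earlier step, since compound 3 already gives 80 nM and the two changes may not add in full. Compound 4 is estimated at 20 nM, between 5 nM and 80 nM.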

Compound 4, half-maximal inhibitory concentration: 50 nM
Estimate against measurement, compound 4: 2.5-fold (0.40 log units) below; the measured number falls inside the stated range.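

In this assay, the change from 2-chlorophenyl to 3-bromophenyl does not carry over at the same size from the core of compound 1 to the core of compound 3: the same change on two cores in this assay, a 17-fold lower number (1.23 log units; beyond the scatter) from compound 1 to compound 2 and a 1.6-fold lower number (0.20 log units; within the scatter) from compound 3 to compound 4, 11-fold (1.02 log units) apart, beyond the scatter of two such steps. On the core of compound 3, the change gives a 1.6-fold lower number from compound 3 to compound 4 (0.20 log units; within the scatter), so the large step seen on the core of compound 1 cannot be assumed on another core in this series. The result rests on a single pair of aryl groups on two cores, and it does not show why the steps differ or whether the halogen or its placement matters more, since the change replaces both at once.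

Open, on these data alone, is whether a plain phenyl, or a phenyl carrying a nitrile or a carboxylic acid, would also give steps that differ between these two cores. Also open, as far as these compounds go, is whether a longer chain in place of the present one would leave the gap between the two steps as it stands.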